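The source may hold more compounds than are shown below. What is called first, only, known or untested is meant among the compounds shown, and "the series" means these compounds.

Measured in a functional assay on HCT-116 cells (Homo sapiens) for antiproliferative activity, read by MTT assay, with a stated time of 48 h; on this read-out lower numbers stand for stronger inhibition and higher numbers for weaker inhibition:
compound 1 `COc1ccc(CN(C(=O)CSc2nc3ccccc3s2)c2cc(OC)c(OC)c(OC)c2)cc1F` gives 1830 nM
compound 2 `COc1ccc(CN(C(=O)CSc2nc3ccccc3s2)c2cc(OC)c(OC)c(OC)c2)cc1C` gives 17100 nM
compound 3 `COc1cc(CN(C(=O)CSc2nc3ccccc3s2)c2cc(OC)c(OC)c(OC)c2)cc(OC)c1OC` gives 65300 nM

Compound 1 stands lowest of the three numbers in this assay. Its nearest neighbour is compound 2, with a 9.3-fold higher number from compound 1 to compound 2 (0.97 log units; beyond the scatter), and the furthest is compound 3, with a 36-fold higher number from compound 1 to compound 3 (1.55 log units; beyond the scatter). Between the other two the gap is a 3.8-fold higher number from compound 2 to compound 3 (0.58 log units; beyond the scatter).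

Compound 4 `COc1ccc(CN(C(=O)CSc2nc3ccccc3s2)c2cc(OC)c(OC)c(OC)c2)cc1OC` has not been measured. It differs from compound 1 in one place: methoxy in place of fluoro on an aromatic carbon. For the measured compounds named here, two measured steps bear on this change. The step of a 9.3-fold higher number from compound 1 to compound 2 (0.97 log units; beyond the scatter) puts a methyl in place of the same fluoro on the same aromatic carbon and raises the number well beyond the scatter. The step of a 36-fold higher number from compound 1 to compound 3 (1.55 log units; beyond the scatter) goes to 3,4,5-trimethoxyphenyl, which contains the 3,4-dimethoxyphenyl of compound 4 together with one more methoxy, and raises the number still further. Both replacements of the fluoro at this carbon gave weaker inhibition, so a modest step towards a higher number is expected for compound 4, smaller than for compound 3, in the region of compound 2.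

Compound 4 is therefore estimated at 12000 nM, within 3500 nM to 40000 nM, which means an expected step of a 6.6-fold higher number from compound 1 to compound 4 (0.82 log units; beyond the scatter).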

Compound 4, half-maximal inhibitory concentration: 33900 nM
Beside the measured number, compound 4's estimate is 2.8-fold (0.45 log units) below it; the range from low to high includes it.
By their numbers in this assay, from the lowest: compound 1; then compounds 2, 4 and 3 (each within the scatter of the next, the first and the last beyond it).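

In this assay, methoxy in place of fluoro on this aromatic carbon, ortho to a methoxy group, gives a 19-fold higher number from compound 1 to compound 4 (1.27 log units; beyond the scatter), so the loss seen with methyl also appears with an oxygen-linked group, and compound 1 now has a number beyond the scatter from all three of the other compounds. Methoxy and methyl at this carbon cannot be told apart, with a 2.0-fold higher number from compound 2 to compound 4 (0.30 log units; within the scatter), and the extra methoxy that separates the 3,4-dimethoxyphenyl from the 3,4,5-trimethoxyphenyl also makes no difference beyond the scatter, with a 1.9-fold lower number from compound 3 to compound 4 (0.28 log units; within the scatter), although the three replacements do not collapse into one level, since compound 2 and compound 3 remain beyond the scatter of each other. No measurement on hand explains why fluoro stands apart from the other groups at this carbon.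

The compounds shown leave open whether fluoro itself is favoured here or whether any group larger than hydrogen is disfavoured, a question that hydrogen, chloro or hydroxy at this carbon would address. They also leave open whether the fluoro result holds with a group other than the 4-methoxy beside it in the name 3-fluoro-4-methoxyphenyl, such as an amine or a longer alkoxy chain.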